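The compounds below may be only part of what the source reports. "The series", "measured", "known", "first", "only" and "open" are said of these compounds alone.

Compound 1 `O=C(O)C12CC(CN3CCC[C@H](O[C@H](CO)c4cc(Cl)cc(Cl)c4)[C@@H]3c3ccccc3)(C1)C2` is one of three compounds examined in an assay on isolated protein for activation of cGMP-dependent protein kinase 1 (Homo sapiens), read by ADP-Glo, with stated times of 30 min and 2 h, in the presence of a further agent that is not named here; a higher number here means that more compound is needed for the effect, a lower number that less compound is needed. In this assay compound 1 gives 12000 nM, which sits level with compound 2 `Cc1cc(C(=O)O)ccc1CN1CCC[C@H](O[C@H](CO)c2cc(Cl)cc(Cl)c2)[C@@H]1c1cccc(F)c1` at 12000 nM; these two numbers are together the lowest of the three, and since they lie within the scatter of each other no order can be read between them. Compound 3 `Cc1cc(C(=O)O)ccc1CN1C(C)CC[C@H](O[C@H](CO)c2cc(Cl)cc(Cl)c2)[C@@H]1c1ccccc1` gives 36000 nM, a number that lies beyond the scatter above that of compound 1.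

Compound 4 `O=C(O)c1ccc(CN2CCC[C@H](O[C@H](CO)c3cc(Cl)cc(Cl)c3)[C@@H]2c2ccccc2)c(C2CC2)c1` has not yet been measured. It differs from compound 1 as follows: a group of 12 heavy atoms (10 carbon, 2 oxygen; one three-membered non-aromatic ring of carbon only, one six-membered aromatic ring of carbon only) in place of a group of 8 heavy atoms (6 carbon, 2 oxygen; 2 four-membered non-aromatic rings of carbon only), on a saturated chain carbon bound to an amine nitrogen in a ring. Among the compounds with values here, no measured pair shows this particular exchange, so its effect can only be expected rather than read off. A small movement is expected because compound 2 with 12000 nM also bears a six-membered aromatic ring at this place and matches compound 1 at 12000 nM. Compound 4 is therefore expected to give 10000 nM, within a range from 4000 nM to 30000 nM. The expected step of a 1.2-fold lower number from compound 1 to compound 4 (0.08 log units; within the scatter) is judged to be within the scatter, with no clear direction.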

Compound 4, half-maximal effective concentration: 1800 nM
The estimate for compound 4 lay 5.6-fold (0.74 log units) above the measured number; the whole stated range lies above it.
By their numbers in this assay, from the lowest: compound 4; then compounds 1 and 2 (each within the scatter of the next); then compound 3.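

Within the data shown here, the exchange gives the first readable step, a 6.7-fold lower number from compound 1 to compound 4 (0.82 log units; beyond the scatter) in this assay, and shows that the group on the saturated chain carbon bound to an amine nitrogen in a ring can change the number beyond the scatter. Both groups carry the same counts of hydrogen-bond donors, hydrogen-bond acceptors and double bonds outside aromatic rings and no net charge, so these counts do not distinguish them, while the ring types and heavy-atom counts do. No measurement shown here explains the step.

As far as these compounds go, the exchange brings in the three-membered ring and the six-membered aromatic ring together, so the share of each in the step remains open. Also open, from the compounds shown here alone, is whether an isopropyl group or a chlorine atom in place of the three-membered ring would give a similar number in this assay.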